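This account rests on a few compounds, and the source may have more. Where it says the series, first, only, none or still open, it means among the compounds named here.

For the measured compounds named here, in a functional assay on HCT-116 cells (Homo sapiens) for inhibition, read by MTT assay, with a stated time of 48 h (on this read-out lower numbers stand for stronger inhibition and higher numbers for weaker inhibition), compound 3 `COc1ccc(CN(C(=O)C=C(C)C)c2cc(OC)c(OC)c(OC)c2)cc1O` gives 290 nM, the lower of the two true numbers measured so far. The other is from compound 1 `C/C=C/C(=O)N(Cc1ccc(OC)c([N+](=O)[O-])c1)c1cc(OC)c(OC)c(OC)c1`, at 670 nM, and the gap between them lies beyond the usual scatter of repeated measurements. Compound 2 `COc1cc(NCc2ccc(Cl)cc2)cc(OC)c1OC` reads > 80000 nM, and this entry is a limit of the assay, not a number.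

The next compound to be tested is compound 4 `COc1ccc(CN(C(=O)CO)c2cc(OC)c(OC)c(OC)c2)cc1O`. It keeps the rest of compound 3 but carries hydroxymethyl in place of 2-methylprop-1-en-1-yl on a carbonyl carbon whose other neighbour is an amide-type nitrogen (hydroxymethyl in place of 2-methylprop-1-en-1-yl on a carbonyl carbon). The group that leaves holds a double bond, and the group that enters does not.

Going by the values given here, no measured compound has hydroxymethyl at this place, so any forecast here is a judgement made from very little data. It leans on compound 3 at 290 nM and compound 1 at 670 nM, the two measured compounds with a double bond in the chain on this carbonyl. In this assay, the expected change is a move toward weaker inhibition, beyond the scatter, with an estimated size of a 10-fold higher number from compound 3 to compound 4 (1.01 log units; beyond the scatter). For compound 4 the estimated value is 3000 nM, with an expected range of 400 nM to 25000 nM.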

Compound 4, half-maximal inhibitory concentration: 520 nM
Beside the measured number, compound 4's estimate is 5.8-fold (0.76 log units) above it; the measured number falls inside the stated range.
By their numbers in this assay, from the lowest: compounds 3, 4 and 1 (each within the scatter of the next, the first and the last beyond it). At a limit, above all of these: compound 2.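

In this assay, putting hydroxymethyl in place of 2-methylprop-1-en-1-yl on the carbonyl carbon gives a 1.8-fold higher number from compound 3 to compound 4 (0.25 log units; within the scatter), so this assay cannot tell the two compounds apart. Until now, every measured compound with a chain on this carbonyl carried a double bond in that chain, so the double bond could have been essential for inhibition at this level. Compound 4 shows that it is not: a group with fewer heavy atoms, no double bond, and one hydrogen-bond donor and one acceptor still leaves the number within the scatter of compound 3, although nothing shown here explains why.

For the compounds shown here, only one single-place change at this position can be read so far, so it remains open how far the result extends to other groups, such as a plain methyl, an aminomethyl, a carboxylic acid or a longer chain ending in a hydroxyl. From the compounds shown here alone, it is also open whether the hydroxyl of hydroxymethyl contributes at all, or whether the position simply accepts a range of small groups on this carbonyl carbon.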